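Oxazole-piperazine amides: microsomal stability, next compound

This account rests on a few compounds, and the source may have more. Where it says the series, first, only, none or still open, it means among the compounds named here.

Measured so far:
compound 1 `COc1cc(OC)cc(N2CCN(C(=O)c3oc(C)nc3-c3cccc(F)c3)CC2)c1`, 11.6%
compound 2 `Cc1nc(-c2ccccc2F)c(C(=O)N2CCN(c3cc(Cl)cc(Cl)c3)CC2)o1`, 49%
compound 3 `Cc1nc(-c2ccccc2)c(C(=O)N2CCN(c3cccc(C)c3C)CC2)o1`, 83.6%

All three values come from an ADME assay on microsomes from liver (Mus musculus) for metabolic stability, read by LC-MS, with a stated time of 1 h, tested at 5 uM; on this read-out lower numbers stand for a less stable compound and higher numbers for a more stable compound. Compound 2 holds the middle place of the three: compound 3 sits higher, beyond the scatter, and compound 1 sits lower, also beyond the scatter. Among the measured compounds shown here, the next compound is compound 4 `Cc1nc(-c2cccc(F)c2)c(C(=O)N2CCN(c3cc(Cl)cc(Cl)c3)CC2)o1`, which keeps the core and the piperazine substituent of compound 2 and changes only one group: 3-fluorophenyl in place of 2-fluorophenyl on an aromatic carbon. For the measured compounds named here, no measured pair shows this change on its own, so its size cannot be read from the data. Compound 1 carries the same 3-fluorophenyl group but differs elsewhere too, so it gives no clean guide. For compound 4 the expected step is a number 6 percentage points lower from compound 2 to compound 4 (within the scatter), a shift not clearly beyond the scatter, with a wide band around the estimate 43% (range 18% to 70%) in this assay.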

Compound 4, percent of the compound remaining: 40.7%
Estimate against measurement, compound 4: 2.3 percentage points above; measured number inside the range.
By their numbers in this assay, from the lowest: compound 1; then compounds 4 and 2 (each within the scatter of the next); then compound 3.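

In this assay the swap of 2-fluorophenyl for 3-fluorophenyl on the aromatic carbon next to the ring nitrogen gives a number 8.3 percentage points lower from compound 2 to compound 4 (within the scatter) and so does not separate the two compounds at this position. Among the compounds shown here, with 3-fluorophenyl held, 3,5-dichlorophenyl in place of 3,5-dimethoxyphenyl on the amine nitrogen in a ring gives a number 29.1 percentage points higher from compound 1 to compound 4 (beyond the scatter) and is the first single-place step beyond the scatter. No measured evidence bears on either step.

Still open, as far as these compounds go, is how a nitrile or a trifluoromethyl group on the phenyl ring at this position would read in this assay and whether the step on the amine nitrogen carries over to the 2-fluorophenyl compounds.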